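A few compounds are considered here, and "the series" means these few. Any claim that something is new, unique, unknown or untested is made for them only; others in the source may bear on it.

Compound 1 `O=C(Nc1ccccc1C(F)(F)F)N1CCC(c2nc(-c3ccc4ccccc4n3)no2)CC1`: 700 nM
Compound 2 `O=C(Nc1ncccc1Cl)N1CCC(c2nc(-c3ccc4ccccc4n3)no2)CC1`: 2800 nM
Compound 3 `CC(=O)N1CCC(NC(=O)N2CCC(c3nc(-c4ccc5ccccc5n4)no3)CC2)CC1`: 500 nM

These three compounds share one core and differ only in the group on an amide-type nitrogen, all measured in a functional assay on Shh Light II cells (Mus musculus) for inhibition, read by a luciferase reporter; on this read-out lower numbers stand for stronger inhibition and higher numbers for weaker inhibition. Compound 3 has the lowest number of the three, though its step to compound 1, a 1.4-fold lower number from compound 1 to compound 3 (0.15 log units; within the scatter), is within the scatter; only compound 2 stands clearly apart, with a 5.6-fold lower number from compound 2 to compound 3 (0.75 log units; beyond the scatter). Compound 4 `CC(C)c1ccccc1NC(=O)N1CCC(c2nc(-c3ccc4ccccc4n3)no2)CC1` is not yet measured; it differs from compound 3 by 2-isopropylphenyl in place of 1-acetylpiperidin-4-yl on an amide-type nitrogen. The step most like this one is a 1.4-fold lower number from compound 1 to compound 3 (0.15 log units; within the scatter): compound 1 also carries a six-membered aromatic ring of carbon only on that nitrogen, and that step stayed within the scatter. The expected step of a 1.4-fold higher number from compound 3 to compound 4 (0.15 log units; within the scatter) is therefore small. Compound 4 is estimated at 700 nM, with a range of 250 nM to 2000 nM.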

Compound 4, half-maximal inhibitory concentration: 480 nM
Compound 4: the middle estimate sits 1.5-fold (0.16 log units) above what was measured; the range from low to high includes it.
By their numbers in this assay, from the lowest: compounds 4, 3 and 1 (each within the scatter of the next); then compound 2.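

Placing an all-carbon aromatic ring where a non-aromatic ring stood leaves the number level in this assay, with a 1.0-fold lower number from compound 3 to compound 4 (0.02 log units; within the scatter), so this nitrogen carries 2-isopropylphenyl and 1-acetylpiperidin-4-yl equally well. Isopropyl in place of trifluoromethyl on the aromatic carbon also stays within the scatter, with a 1.5-fold lower number from compound 1 to compound 4 (0.16 log units; within the scatter), while a 5.8-fold lower number from compound 2 to compound 4 (0.77 log units; beyond the scatter) keeps compound 2 clearly apart. No supporting measurement is available to explain these results.

From the compounds shown here alone, whether a plain phenyl, or a ring bearing a carboxylic acid or an amine, would stay level remains open. So does which feature of 3-chloropyridin-2-yl separates compound 2.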